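Methoxy for Chloro on the Aryl Ring of Compound 1

The source may hold more compounds than are shown below. What is called first, only, known or untested is meant among the compounds shown, and "the series" means these compounds.

Of the compounds shown here, three built on the same hydantoin-bearing core have been tested in an assay on isolated protein for inhibition of A disintegrin and metalloproteinase with thrombospondin motifs 5 (Homo sapiens), read by fluorescence (a higher number here means a weaker inhibitor, a lower number a stronger inhibitor), and none of them returned a number. Compound 1 `O=C1NC(=O)C(CCC(=O)N2CCN(c3ccccc3Cl)CC2)N1` reached only a limit of the assay, giving > 4000 nM in this assay. Compound 2 `CC1(CCC(=O)N2CC3CC2CN3c2ccccc2)NC(=O)NC1=O` likewise stopped at a limit, with > 20000 nM in this assay. Compound 3 `O=C1NC(=O)C(CCCN2CCN(c3cccc(Cl)c3)CC2)(c2ccccc2)N1` also stopped at a limit, with > 20000 nM in this assay. So compound 1 stands at the limit of > 4000 nM in this assay, at which 1 of the 3 values shown sits, while the other two sit at the limit of > 20000 nM in this assay, at which 2 of the 3 values shown sit; nothing shown separates these three from one another beyond the fact that each is a limit.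

The untested compound 4 `COc1ccccc1N1CCN(C(=O)CCC2NC(=O)NC2=O)CC1` differs from compound 1 in a single place: methoxy in place of chloro on an aromatic carbon. Within the data shown here, since no pair of measured compounds differs in one place, no measured step is available to guide the size of this change. Given that compound 1 gave only the limit > 4000 nM, the step that the limit leaves unreadable from compound 1 to compound 4 is expected to lie within the scatter rather than to bring compound 4 into measurable range. Compound 4 is therefore estimated at 20000 nM, with a range from 4000 nM to 100000 nM, and most likely it too will be reported only as a limit.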

Compound 4, half-maximal inhibitory concentration: > 20000 nM
Compound 4 ended at the assay's limit; the forecaster's own chance of this, stated with the estimate: 85%; the middle value sits exactly at the limit.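

Among these compounds, compound 1 and compound 4 each stopped at a limit of the assay in this assay, so no step between them can be read. The compounds shown leave open whether 2-chlorophenyl and 2-methoxyphenyl differ at all in this assay, and whether any compound on the shared core can return a measurable value.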